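This account rests on a few compounds, and the source may have more. Where it says the series, first, only, none or still open, it means among the compounds named here.

Measured so far:
compound 1, `NCc1csc(NC(=O)c2cnn[nH]2)n1`, > 100 ug/mL in a physicochemical assay for solubility, read by nephelometry, measured as kinetic solubility, at pH 2.0; on this read-out higher numbers stand for higher solubility and lower numbers for lower solubility
compound 2, `CC(C)(C)c1cc(C(=O)Nc2ccccn2)n(Cc2ccccc2)n1`, 25 ug/mL in this assay

Compound 1 carries the structure `NCc1csc(NC(=O)c2cnn[nH]2)n1`, and in this assay compound 1 reaches only a limit, > 100 ug/mL, which is a boundary of the assay and not a number. For the measured compounds named here, compound 2, `CC(C)(C)c1cc(C(=O)Nc2ccccn2)n(Cc2ccccc2)n1`, is the one compound with a proper reading, 25 ug/mL in this assay. Compound 2 stands alone as the sole numerical point, and the limit of > 100 ug/mL in this assay, at which 1 of the 2 values shown sits, is the only further evidence shown.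

Compound 3, `CC(C)(C)c1cc(C(=O)Nc2nc(CO)cs2)n(Cc2ccccc2)n1`, has not yet been measured. It differs from compound 2 in one place: 4-(hydroxymethyl)-1,3-thiazol-2-yl in place of pyridin-2-yl on an amide-type nitrogen. No step between measured compounds is shown, so there is nothing to calibrate this change against. It is expected that compound 3 moves modestly upward from compound 2, by a step of a 1.6-fold higher number from compound 2 to compound 3 (0.20 log units; within the scatter) in this assay, although a step of that size need not clear the usual scatter. The estimate for compound 3 is 40 ug/mL, with a range from 12 ug/mL to 120 ug/mL.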

Compound 3, solubility: 12.5 ug/mL
The estimate for compound 3 lay 3.2-fold (0.51 log units) above the measured number, within the range that was stated.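

In this assay, for the compounds shown here, the exchange of pyridin-2-yl for 4-(hydroxymethyl)-1,3-thiazol-2-yl on the amide-type nitrogen gives the first step that can be read at this position, a 2.0-fold lower number from compound 2 to compound 3 (0.30 log units; within the scatter). The shared core is kept while both the ring and its substituent are replaced, yet this read-out does not separate the two compounds, so a five-membered aromatic ring bearing a hydroxymethyl group is tolerated here without a difference that clears the usual scatter. Nothing shown offers an explanation for this step, and the single limit on record does not bear on this exchange.

The ring and the hydroxymethyl group entered together, so the compounds shown leave open what each contributes alone, a question that the plain 1,3-thiazol-2-yl group would address directly. Also open, going by these compounds, is whether a carboxylic acid or a methoxymethyl group in place of the hydroxymethyl would give a step beyond the scatter, since a single exchange at this position cannot show how far the read-out can move there.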